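Hepatocyte clearance notes: compound 2 to compound 4

This account rests on a few compounds, and the source may have more. Where it says the series, first, only, none or still open, it means among the compounds named here.

Measured so far:
compound 1 `CC(C)n1cc(-c2ccnc3[nH]c(C4CCN(CC(=O)N5CCCC5)CC4)cc23)ccc1=O`: 5.4 uL/min
compound 2 `CC(C)Cn1cc(-c2ccnc3[nH]c(C4CCN(CC(=O)N(C)C)CC4)cc23)ccc1=O`: 6.6 uL/min
compound 3 `COc1cc(C(=O)N2CCCC2)ccc1-c1ccnc2[nH]c(C3CCNCC3)cc12`: < 1 uL/min

In an ADME assay on cells (Hepatocyte, Rattus norvegicus) for metabolic stability (a lower number here means slower removal, a higher number faster removal of the compound), compound 2 gives 6.6 uL/min. Compound 1 gives 5.4 uL/min in this assay, and the two numbers sit within the scatter of each other, so no order between them can be read. Compound 3 gives only a limit, < 1 uL/min in this assay (the limit of < 1 uL/min in this assay, at which 1 of the 3 values shown sits). Compound 2 thus holds the higher of the two numbers shown, but it stands on a par with compound 1.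

Compound 4 `CN(C)C(=O)CN1CCC(c2cc3c(-c4ccc(=O)n(CC5CCOCC5)c4)ccnc3[nH]2)CC1` is not yet measured. It differs from compound 2 as follows: oxan-4-yl in place of isopropyl on a saturated chain carbon bound to an aromatic nitrogen. For the measured compounds named here, no measured pair in this set shows a change of this kind, so there is no step to lean on.

Compound 4 is expected to give 5 uL/min, with a range from 2 uL/min to 12 uL/min. The expected step of a 1.3-fold lower number from compound 2 to compound 4 (0.12 log units; within the scatter) is small, none beyond the scatter, although a turn toward a lower number is not excluded.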

Compound 4, intrinsic clearance in a liver preparation (reported as CLH), per the amount of preparation that the assay uses: 1.8 uL/min
Compound 4: the middle estimate sits 2.8-fold (0.44 log units) above what was measured, and the stated range ends above it.
By their numbers in this assay, from the lowest: compound 4; then compounds 1 and 2 (each within the scatter of the next). At a limit, below all of these: compound 3.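

In this assay, the group on a saturated chain carbon bound to an aromatic nitrogen proves able to shift the read-out: oxan-4-yl in place of isopropyl gives a 3.7-fold lower number from compound 2 to compound 4 (0.56 log units; beyond the scatter). For the compounds shown here, the earlier compounds differ from one another in more than one place and offered no step at this position, so this single pair is the first reading of it, with isobutyl giving way to (oxan-4-yl)methyl. Nothing measured in the set accounts for the step.

The pair changes the ring, the oxygen and the size of the group together, and the share of each cannot be read. Also open, from the compounds shown here alone, is how an all-carbon cyclohexyl or a basic piperidin-4-yl amine would behave at the same place.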